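A few compounds are considered here, and "the series" means these few. Any claim that something is new, unique, unknown or untested is made for them only; others in the source may bear on it.

Compound 1, with the structure `Nc1nnc(CCSCCc2nnc(N)s2)s1`, and compound 2, with the structure `Nc1nnc(CCCCc2nnc(NC(=O)CCc3ccccc3)s2)s1`, share a core carrying two aminothiadiazole ends, and both were tested in an assay on isolated protein for inhibition of glutaminase kidney isoform, mitochondrial (Homo sapiens), with a stated time of 45 min; a lower number here means a stronger inhibitor, a higher number a weaker inhibitor. In this assay compound 1 gives 100000 nM. Compound 2 is reported only as a limit in this assay, at > 100000 nM, so no number stands for it. The weaker of the two readings sits at the limit of > 100000 nM in this assay, at which 1 of the 2 values shown sits, and nothing closer to the low end of the scale has been seen among these two. Compound 3, with the structure `Nc1nnc(CCCCc2nnc(NC(=O)CC3CCCCC3)s2)s1`, differs from compound 2 in one place: cyclohexyl in place of benzyl on a saturated chain carbon bound to a carbonyl carbon, so the amide side chain keeps its length and its carbonyl, and only the ring at its end changes. With compound 2 at the limit and compound 1 at the edge of the measured range, no step beyond the usual scatter is expected from compound 2 to compound 3 in this assay, in either direction. For compound 3 the estimate in this assay is 100000 nM, within a range from 30000 nM to 300000 nM, and the step of a number no higher from compound 2 to compound 3 (the limit leaves the size open) is expected to be flat.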

Compound 3, half-maximal inhibitory concentration: 22000 nM
Estimate against measurement, compound 3: 4.5-fold (0.66 log units) above, and the stated range ends above it.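

In this assay, among these compounds, the ring at the end of the amide side chain proves not to be indifferent, a point the earlier compounds could not show: cyclohexyl in place of benzyl on a saturated chain carbon bound to a carbonyl carbon gives an at least 4.5-fold lower number from compound 2 to compound 3 (0.65 log units; beyond the scatter). The change is not a pure swap of an aromatic ring for a non-aromatic one, since the 7 heavy atoms of benzyl give way to the 6 of cyclohexyl, and this single step cannot separate the two differences. Compound 2 stands at a limit and not at a number, so the full size of the step stays open: the limit of > 100000 nM in this assay, at which 1 of the 3 values shown sits.

The compounds shown leave open whether the lower number in this assay follows from the loss of aromaticity or from the change in heavy atoms, and a longer chain carrying the same cyclohexyl would bear on that question. They also leave open how an amine or a carboxylic acid on that ring would read here, and whether the other aminothiadiazole end tolerates an amide of its own.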